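This account rests on a few compounds, and the source may have more. Where it says the series, first, only, none or still open, it means among the compounds named here.

Measured compounds:
- Compound 1, `Cc1ccc2snc(/N=C\c3ccccc3O)c2c1`: 5000 nM
- Compound 2, `COc1cccc(/C=N\c2nsc3ccccc23)c1O`: 5000 nM

Compound 1 and compound 2 were both tested in a functional assay on MT4 cells (Homo sapiens) for antiproliferative activity, read by MTT assay, with a stated time of 96 h; a higher number here means a weaker inhibitor, a lower number a stronger inhibitor. In this assay compound 1 gives 5000 nM, and compound 2 gives 5000 nM. The two values are the same at the digits shown, so compound 1 stands level with compound 2, and nothing separates them beyond the ordinary run-to-run variation of the measurement.

Compound 3, `Cc1ccc2snc(/N=C\c3ccccc3Cl)c2c1`, has not yet been tested. It differs from compound 1 in one place: chloro in place of hydroxy on an aromatic carbon. Going by the values given here, no pair of measured compounds that differ in a single place is available, so there is no measured step to lean on for this kind of swap.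

Both measured compounds sit at the same weak level, and nothing in the data points to a change of any size in either direction. The expectation for compound 3 is therefore a step of no change at the digits printed from compound 1 to compound 3 (within the scatter), that is, none beyond the scatter. Compound 3 is estimated to give 5000 nM in this assay, within a range from 2500 nM to 20000 nM.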

Compound 3, half-maximal inhibitory concentration: 3000 nM
Estimate against measurement, compound 3: 1.7-fold (0.22 log units) above; the measured number falls inside the stated range.
By their numbers in this assay, from the lowest: compounds 3, 1 and 2 (each within the scatter of the next).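

Going by these compounds alone, this is the first measured step at this position: on an aromatic carbon of a six-membered aromatic ring of carbon only, ortho to a large group, chloro in place of hydroxy gives, in this assay, a 1.7-fold lower number from compound 1 to compound 3 (0.22 log units; within the scatter). The swap is a real change in what sits at this place, since hydroxy carries 1 hydrogen-bond donor and 1 hydrogen-bond acceptor, while chloro carries 0 of either, yet the two compounds cannot be told apart in this measurement, so at this level of activity the hydroxy is not required in this series. No measurement shown here gives a reason for this outcome.

As far as these compounds go, one swap at one position still says little about how far this place can be changed, and it remains open whether an amine, a carboxylic acid or a longer chain here would separate itself from compound 1 by more than the scatter. From the compounds shown here alone, it is also open whether chloro would give a similar result on a different carbon of this ring or on the core of compound 2.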